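Working notes: 4-nitrobenzyl in place of 4-bromophenyl

The source may report more compounds than this note shows. Statements on the series, on what has been measured and on what is new or still open speak of the compounds shown alone.

Compound 1 `Cc1c(-n2cc(COc3ccc(/C=C/C(=O)c4cc5c(cc4O)OC(C)(C)CC5)cc3)nn2)cccc1[N+](=O)[O-]`: 176000 nM
Compound 2 `CC1(C)CCc2c(ccc(C(=O)/C=C/c3ccc(OCc4cn(-c5ccc(Br)cc5)nn4)cc3)c2O)O1`: "not active" (no number reported)
Compound 3 `CCCCCCCCn1cc(COc2ccc(/C=C/C(=O)c3cc4c(cc3O)OC(C)(C)CC4)cc2)nn1`: "not active" (no number reported)

All three readings come from a functional assay on MCF7 cells (Homo sapiens) for antiproliferative activity, read by MTT assay; a higher number here means a weaker inhibitor, a lower number a stronger inhibitor. Compound 2 has no single number there and is reported as "not active" (no number reported). Compound 3 is likewise reported as "not active" (no number reported). Only compound 1 gives a number, 176000 nM, so compound 2 cannot be ranked by size against the others.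

Unmeasured so far is compound 4 `CC1(C)CCc2c(ccc(C(=O)/C=C/c3ccc(OCc4cn(Cc5ccc([N+](=O)[O-])cc5)nn4)cc3)c2O)O1`. The change is 4-nitrobenzyl in place of 4-bromophenyl on an aromatic nitrogen of a five-membered aromatic ring with 3 nitrogen. Among the measured compounds shown here, with no number for compound 2, no step can be read from it, and no step between measured compounds is available as a guide. The expected step in this assay is small and towards a stronger inhibitor: a move from no reported number to the weak level of compound 1 at 176000 nM, a compound that also carries a nitro group, though its core differs from that of compound 2. A large gain is not expected, and another result without a number remains quite possible. For compound 4 the estimated value is 100000 nM, with an expected range from 30000 nM to 300000 nM.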

Compound 4, half-maximal inhibitory concentration: 17100 nM
Beside the measured number, compound 4's estimate is 5.8-fold (0.77 log units) above it; the measured number lies below the stated range.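

Among the compounds shown here, compound 2 is reported as not active without a number in this assay, and no step to compound 4, at 17100 nM, can be read. The compounds shown leave open how far 4-nitrobenzyl and 4-bromophenyl on the shared core differ in numerical terms. Nothing available here offers an explanation for the result of compound 4.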